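This account rests on a few compounds, and the source may have more. Where it says the series, first, only, none or still open, it means among the compounds named here.

Among the compounds with values here, the series shares one core bearing a six-membered aromatic ring of carbon only, and the three compounds measured so far differ only in the group on that ring. Compound 1 `Clc1ccc(-c2n[nH]cc2N2CCCNCC2)cc1` carries chloro. In an assay on isolated protein for binding affinity to 5-hydroxytryptamine receptor 1E (Homo sapiens) (a higher number here means a weaker inhibitor, a lower number a stronger inhibitor), compound 1 gives > 10000 nM, which is a limit of the assay and not a number. Compound 2 `Fc1cccc(-c2n[nH]cc2N2CCCNCC2)c1` carries fluoro. In this assay compound 2 gives > 10000 nM, again only a limit. Compound 3 `COc1ccccc1-c1n[nH]cc1N1CCCNCC1` carries methoxy. In this assay compound 3 gives > 10000 nM, also a limit. Within the data shown here, compound 1 therefore stands nowhere that a number could fix: all three values sit at the limit of > 10000 nM in this assay, at which 3 of the 3 values shown sit, so nothing separates compounds 1, 2 and 3 from one another, and no measured step between any pair of them exists.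

Compound 4 `COc1ccc(-c2n[nH]cc2N2CCCNCC2)cc1` differs from compound 1 by methoxy in place of chloro on an aromatic carbon. Among the measured compounds shown here, no step between measured compounds is at hand to size this change. For the measured compounds named here, because every value so far sits at the limit of > 10000 nM in this assay, at which 3 of the 3 values shown sit, the step from compound 1 to compound 4 in this assay is expected to be a step that the limit leaves unreadable from compound 1 to compound 4, nothing beyond the scatter in either direction. Compound 4 is accordingly estimated at 15000 nM in this assay. For compound 4 the expected range runs from 5000 nM to 50000 nM, and most likely the assay again reports only a limit.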

Compound 4, inhibition constant: > 10000 nM
Compound 4: a limit, no number; the forecaster's own chance of this, stated with the estimate: 85%; the middle value lies beyond the limit too.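

In this assay compound 4 gives > 10000 nM, a limit of the assay and not a number. No step can be read between compound 1 and compound 4, because both rest at the same limit: the limit of > 10000 nM in this assay, at which 4 of the 4 values shown sit. The compounds shown leave open whether any group on the shared core gives a readable value in this assay.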